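Cytotoxicity on rat L6 cells: amidine to imidazoline exchange

A few compounds are considered here, and "the series" means these few. Any claim that something is new, unique, unknown or untested is made for them only; others in the source may bear on it.

Measured so far:
compound 1 `CC(C)NC(=N)c1ccc2oc(-c3cccc(OCCCCCOc4ccccc4)c3)cc2c1`: 10100 nM
compound 2 `c1ccc(OCCCCCOc2cccc(-c3cc4cc(C5=NCCN5)ccc4o3)c2)cc1`: 2600 nM
compound 3 `CC(C)NC(=N)c1ccc2oc(-c3ccc(OCCCCCOc4ccccc4)cc3)cc2c1`: 20500 nM

All three were run in an ADME assay on L6 cells (Rattus norvegicus) for cytotoxicity, read by resazurin assay, with a stated time of 70 h; a lower number here means a stronger inhibitor, a higher number a weaker inhibitor. Compound 1 gives 10100 nM in this assay, and compound 3 gives 20500 nM, the higher of the two; compound 1 and compound 3 have the same atoms joined differently, and the difference between the two cores is not broken down here. Compound 2 gives 2600 nM, the lowest number of the three.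

Among the compounds with values here, the one change made within the measured set is a group of 5 heavy atoms (3 carbon, 2 nitrogen; one five-membered non-aromatic ring with 2 hetero atoms) in place of a group of 6 heavy atoms (4 carbon, 2 nitrogen; no ring), on an aromatic carbon. Its effect: a 3.9-fold lower number from compound 1 to compound 2 (0.59 log units; beyond the scatter).

Compound 4 `c1ccc(OCCCCCOc2ccc(-c3cc4cc(C5=NCCN5)ccc4o3)cc2)cc1` is not yet measured. It carries the same change on the core of compound 3: a group of 5 heavy atoms (3 carbon, 2 nitrogen; one five-membered non-aromatic ring with 2 hetero atoms) in place of a group of 6 heavy atoms (4 carbon, 2 nitrogen; no ring), on an aromatic carbon. The place is described in the same words for both pairs, so this is taken as the same change, now on a different core. The expectation for compound 4 rests on one pair only, so the step is taken over with no claim of a pattern beyond these compounds. Because of a 3.9-fold lower number from compound 1 to compound 2 (0.59 log units; beyond the scatter), the step is taken over unchanged. For compound 4 the expected step is then a 3.9-fold lower number from compound 3 to compound 4 (0.59 log units; beyond the scatter), set beside the measured one. In this assay compound 4 is then expected to give about 5300 nM, with a range estimated from 2500 nM to 11000 nM.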

Compound 4, half-maximal inhibitory concentration: 900 nM
The estimate for compound 4 lay 5.9-fold (0.77 log units) above the measured number; the whole stated range lies above it.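

In this assay the amidine to imidazoline exchange lowers the number on both cores, and on the second core it gives a 23-fold lower number from compound 3 to compound 4 (1.36 log units; beyond the scatter). The direction of the step carries from one core to the other, but its size does not: the same change on two cores in this assay, a 3.9-fold lower number (0.59 log units; beyond the scatter) from compound 1 to compound 2 and a 23-fold lower number (1.36 log units; beyond the scatter) from compound 3 to compound 4, 5.9-fold (0.77 log units) apart, beyond the scatter of two such steps For this series, the two pairs show that the size of the step cannot be taken over unchanged from one core to another; they do not show what in the cores sets the size, and they give no rule for any further core.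

Left open is whether the larger or the smaller step is the more usual one, which would take further matched pairs, for instance with a longer chain in place of the present linker or with a chlorine on the terminal phenyl ring. Also open is how a simple unsubstituted amidine, a six-membered cyclic amidine or a plain amine would compare with the two groups shown, on either core.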